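Adding chlorine to a sulfamoylamino benzamide

This account rests on a few compounds, and the source may have more. Where it says the series, first, only, none or still open, it means among the compounds named here.

Compound 1 `CCN1CCCC1CNC(=O)c1cc(N(C)S(C)(=O)=O)c(Cl)cc1OC`: 7.7 mg/kg
Compound 2 `CCN1CCCC1CNC(=O)c1cc(NS(=O)(=O)N(C)C)c(Cl)cc1OC`: 8.3 mg/kg
Compound 3 `CCN1CCCC1CNC(=O)c1cc(NS(N)(=O)=O)ccc1OC`: > 50 mg/kg

Of the compounds shown here, three have been tested in a functional assay on the whole organism for inhibition, with Mus musculus as the target; on this read-out higher numbers stand for an effect only at larger amounts of compound and lower numbers for an effect already at smaller amounts. Compound 1 gives 7.7 mg/kg in this assay. Among the compounds with values here, compound 2 gives 8.3 mg/kg, and the only measured step, a 1.1-fold higher number from compound 1 to compound 2 (0.03 log units; within the scatter), joins these two. For compound 3 this assay reports only a limit, > 50 mg/kg, and not a number; its standing is therefore known only as lying at that limit, as the line the limit of > 50 mg/kg in this assay, at which 1 of the 3 values shown sits, records.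

Compound 4 `CCN1CCCC1CNC(=O)c1cc(NS(N)(=O)=O)c(Cl)cc1OC` is not yet measured. It differs from compound 3 by chloro in place of hydrogen on an aromatic carbon. Within the data shown here, no measured step changes a hydrogen into a chloro group, so the one measured step does not bear on this change. What the data do show is that compound 1 and compound 2, both carrying a chloro group on the same ring, give numbers in this assay, while compound 3 does not. On that basis compound 4 is expected to give a number rather than a limit, with an expected step of an at least 3.3-fold lower number from compound 3 to compound 4 (0.52 log units; beyond the scatter). The estimate for compound 4 is 15 mg/kg, in a range from 5 mg/kg to 60 mg/kg.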

Compound 4, dose for half-maximal effect: > 50 mg/kg
Compound 4 was reported as a limit; the forecaster's own chance of this, stated with the estimate: 25%; at least 3.3-fold (0.52 log units) between middle value and limit.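

The chloro group alone does not bring a readable number in this assay, and the step between compound 3 and compound 4 cannot be read, since both ends are limits: the limit of > 50 mg/kg in this assay, at which 2 of the 4 values shown sit.

The change on the sulfonyl group, with chloro present, is readable: amino in place of dimethylamino on the sulfonyl sulfur gives an at least 6.0-fold higher number from compound 2 to compound 4 (0.77 log units; beyond the scatter), and sulfamoylamino in place of methyl(methylsulfonyl)amino gives an at least 6.4-fold higher number from compound 1 to compound 4 (0.81 log units; beyond the scatter). Among the three chloro compounds, then, compound 1 and compound 2 give numbers, while compound 4, with the plain sulfamoylamino group, gives only a limit.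

On these data alone, it remains open whether chloro changes the read-out at all in a compound that gives a number. As far as these compounds go, it is also open whether a single methyl on the sulfamoyl nitrogen, as in a methylsulfamoylamino group, would be enough to give a number.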